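The compounds below may be only part of what the source reports. "The series", "measured", "known", "first", "only" and "open" are said of these compounds alone.

Measured so far:
compound 1, `COCC[C@H]1C[C@@H]1c1cncc(N2CCCNCC2)c1`: 17 nM
compound 2, `CN1CCCN(c2cncc(-c3cc(CCO)no3)c2)CC1`: 1040 nM

In an assay on a protein complex for displacement of a labelled ligand from Neuronal acetylcholine receptor; alpha3/beta2 (Rattus norvegicus), read by scintillation counting (a lower number here means a stronger inhibitor, a higher number a weaker inhibitor), compound 1 gives 17 nM, the lowest of the two numbers at hand, while compound 2 gives 1040 nM, a gap that lies well beyond the usual scatter of this kind of measurement. Compound 3, `COCC[C@@H]1C[C@H]1c1cncc(N2CCCNCC2)c1`, has not been measured yet. It is the mirror image of compound 1: the two compounds have the same atoms and bonds and differ only in configuration as drawn: 2 of 2 stereo elements differ (all stereocentres are inverted: mirror images); a stereocentre at a saturated ring carbon is drawn R in compound 1 and S in compound 3; a stereocentre at a saturated ring carbon is drawn S in compound 1 and R in compound 3. Going by the values given here, no measured pair of compounds shows what such an inversion does, so the direction can only be anticipated. Mirror-image pairs frequently differ markedly in binding, and the form already in hand is often the tighter binder, so a step toward weaker binding is expected, estimated as an 8.8-fold higher number from compound 1 to compound 3 (0.95 log units; beyond the scatter). For compound 3 in this assay the estimate is 150 nM, with a likely range from 30 nM to 1500 nM.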

Compound 3, inhibition constant: 15.8 nM
Beside the measured number, compound 3's estimate is 9.5-fold (0.98 log units) above it; measured number below the stated range.
By their numbers in this assay, from the lowest: compounds 3 and 1 (each within the scatter of the next); then compound 2.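

In this assay, inverting both stereocentres at the saturated ring carbons gives a 1.1-fold lower number from compound 1 to compound 3 (0.03 log units; within the scatter), so this assay does not tell the two mirror images apart. Going by these compounds alone, this is the first measured pair to show what such an inversion does, and at this position the full inversion leaves the number within the scatter. The comparison is a clean one, with a single kind of difference to consider: the fact that compounds 1 and 3 differ only in the configuration as drawn

The compounds shown do not reveal what happens when only one of the two stereocentres is inverted. They also leave open whether the mirror images stay this close when the chain on the saturated ring is longer or ends in an amine or a carboxylic acid.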